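Swapping Chloro for Cyano on a Pyridine Amide

The source may report more compounds than this note shows. Statements on the series, on what has been measured and on what is new or still open speak of the compounds shown alone.

Measured compounds:
- compound 1 `CC(=O)N[C@@H]1CCC[C@H](C(=O)Nc2cc(-c3cnn4c3CC(C)(C)C4)ccn2)C1` — < 1 uL/min
- compound 2 `CC(=O)N[C@@H]1CCC[C@H](C(=O)Nc2cc(-c3cnn4c3CC(C)(C)C4)c(Cl)cn2)C1` — 3.5 uL/min

Of the compounds shown here, two have been measured in an ADME assay on cells (Hepatocyte, Homo sapiens) for metabolic stability, using equilibrium dialysis; on this read-out higher numbers stand for fast clearance and lower numbers for slow clearance. Compound 1 gives only a limit of the assay, < 1 uL/min, and 1 of the 2 values shown sits at that limit (the limit of < 1 uL/min in this assay, at which 1 of the 2 values shown sits). Compound 2 gives the only actual number shown, 3.5 uL/min. Among the compounds with values here, the one measured step, an at least 3.5-fold higher number from compound 1 to compound 2 (0.54 log units; beyond the scatter), adds a chloro where compound 1 carries hydrogen and pushes the number beyond the scatter.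

Compound 3 `CC(=O)N[C@@H]1CCC[C@H](C(=O)Nc2cc(-c3cnn4c3CC(C)(C)C4)c(C#N)cn2)C1` has not been measured. It differs from compound 2 in one place: cyano in place of chloro on an aromatic carbon. Within the data shown here, no measured step covers a cyano group, so the chloro step only tells that this position is sensitive to what sits on it. Since the cyano group replaces the very chloro that raised the number from compound 1 to compound 2, a modest move downward is expected rather than a further rise.

In this assay compound 3 is therefore expected to give about 2 uL/min, somewhere between 0.8 uL/min and 4.5 uL/min, which would mean a step of a 1.8-fold lower number from compound 2 to compound 3 (0.24 log units; within the scatter).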

Compound 3, intrinsic clearance in a liver preparation (reported as CLH), per the amount of preparation that the assay uses: < 1 uL/min
Compound 3: no number, only a limit; the forecaster's own chance of this, stated with the estimate: 30%; middle value at least 2.0-fold (0.30 log units) from the limit.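

In this assay, cyano in place of chloro on this aromatic carbon gives an at least 3.5-fold lower number from compound 2 to compound 3 (0.54 log units; beyond the scatter), a change that lies beyond the usual scatter of the assay. This shows that putting a group on this carbon, which sits ortho to a large group and para to a large group, does not by itself bring the higher number: of the two groups shown here, chloro gives a measurable clearance and cyano does not. The step from hydrogen to cyano cannot be read, and compound 1 and compound 3 cannot be put in any order, since each gives only a limit and not a number: the limit of < 1 uL/min in this assay, at which 2 of the 3 values shown sit.

How far the true values of compound 1 and compound 3 lie under that limit stays open, and nothing shown here explains why chloro and cyano differ at this position. Also open, on these data alone, is whether a methyl, a methoxy or an amine on this same carbon would stay at the limit, as cyano does, or give a measurable number, as chloro does.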